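Bromine Added on Two Different Rings of One Core

The source may report more compounds than this note shows. Statements on the series, on what has been measured and on what is new or still open speak of the compounds shown alone.

Measured compounds:
compound 1 `Nc1cccn2cc(Cc3ccccc3)c(=O)nc12` — 98000 nM
compound 2 `O=c1nc2ccccn2cc1Cc1ccccc1` — 104000 nM
compound 3 `Nc1cc(Br)cn2cc(Cc3ccccc3)c(=O)nc12` — > 1000000 nM (a limit of the assay)

All three were tested in a functional assay on A549 cells (Homo sapiens) for cytotoxicity, read by MTT assay, with a stated time of 24 h; a higher number here means a weaker inhibitor, a lower number a stronger inhibitor. The cores of compound 1 and compound 2 differ by hydrogen in place of amino on an aromatic carbon, and the step of a 1.1-fold higher number from compound 1 to compound 2 (0.03 log units; within the scatter) lies within the scatter. For compound 3 the assay reports only a limit, > 1000000 nM. That step, an at least 10-fold higher number from compound 1 to compound 3 (1.00 log units; beyond the scatter), came from bromo in place of hydrogen on an aromatic carbon; compound 3 sits at the limit of > 1000000 nM in this assay, at which 1 of the 3 values shown sits.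

Compound 4 `O=c1nc2ccccn2cc1Cc1ccc(Br)cc1` is not yet measured. It differs from compound 2 by bromo in place of hydrogen on an aromatic carbon. This is the same kind of change as from compound 1 to compound 3, but not the same: there the bromo sits on a six-membered aromatic ring with 1 nitrogen, part of a fused or bridged system of two rings, two atoms from the ring nitrogen, meta to an amino group; in compound 4 it sits on a six-membered aromatic ring of carbon only, para to a large group. Resting only on an at least 10-fold higher number from compound 1 to compound 3 (1.00 log units; beyond the scatter), the step of a 2.9-fold higher number from compound 2 to compound 4 (0.46 log units; beyond the scatter) is expected, held loosely since the place is not the same. Compound 4 is estimated at 300000 nM, between 80000 nM and 1000000 nM.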

Compound 4, half-maximal inhibitory concentration: > 1000000 nM
Compound 4: no number, only a limit; the forecaster's own chance of this, stated with the estimate: 40%; middle value at least 3.3-fold (0.52 log units) away from the limit.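

In this assay compound 4 gives > 1000000 nM, which is a limit of the assay and not a number. Bromo in place of hydrogen on the ring of carbon only gave an at least 9.6-fold higher number from compound 2 to compound 4 (0.98 log units; beyond the scatter), so on both cores shown the change raised the number beyond the scatter, and the two steps compare as follows: the same change on two cores in this assay, an at least 10-fold higher number (1.00 log units; beyond the scatter) from compound 1 to compound 3 and an at least 9.6-fold higher number (0.98 log units; beyond the scatter) from compound 2 to compound 4; the limit leaves it open whether they differ The direction therefore carried from one core to the other, but the true size of neither step is shown, nor whether the place of the bromo matters: the limit of > 1000000 nM in this assay, at which 2 of the 4 values shown sit.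

The compounds shown leave open how a chloro or fluoro group would behave at these places. They also leave open whether a carboxylic acid or a methoxy group there would give a value that can be read as a number.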